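Swapping a methoxyphenyl for a chlorophenyl: predicting clearance

The source may hold more compounds than are shown below. What is called first, only, known or untested is meant among the compounds shown, and "the series" means these compounds.

Three compounds built around a two-ring core carrying a sulfonyl group and an aryl ring have been measured in an ADME assay on microsomes from liver (Homo sapiens) for metabolic stability, tested at 2.5 uM; a higher number here means faster removal of the compound, a lower number slower removal. Compound 1 `O=S(=O)(c1cc(F)cc(F)c1)c1cnc2c(F)cccc2c1-c1cccc(Cl)c1` gives 0.64 mL/min. Compound 2 `COc1ccc(-c2c(S(=O)(=O)c3cc(F)cc(F)c3)cnc3c(F)cccc23)cc1` gives 2.59 mL/min, and compound 3 `COc1ccc(-c2c(S(=O)(=O)c3ccc(C)c(C)c3)cnc3cc(F)ccc23)cc1` gives 4.13 mL/min. Compound 1 and compound 2 differ in a single place: 3-chlorophenyl in place of 4-methoxyphenyl on an aromatic carbon. That change brought a 4.0-fold lower number from compound 2 to compound 1 (0.61 log units; beyond the scatter). The difference between the core of compound 2 and the core of compound 3 is not broken down here.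

Compound 4 `Cc1ccc(S(=O)(=O)c2cnc3cc(F)ccc3c2-c2cccc(Cl)c2)cc1C` has not yet been measured in this assay. It is related to compound 3 by the same change, (3-chlorophenyl in place of 4-methoxyphenyl on an aromatic carbon), made at the same kind of position.

Because the earlier step of a 4.0-fold lower number from compound 2 to compound 1 (0.61 log units; beyond the scatter) was of modest size and beyond the usual scatter, a step of similar size is expected here, a 4.1-fold lower number from compound 3 to compound 4 (0.62 log units; beyond the scatter), resting on that single precedent alone. Starting from compound 3 at 4.13 mL/min, compound 4 is therefore estimated to give 1 mL/min, with a plausible range from 0.5 mL/min to 2.5 mL/min.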

Compound 4, intrinsic clearance in a liver preparation (reported as CLH), per the amount of preparation that the assay uses: 4.01 mL/min
Compound 4: middle estimate off by 4.0-fold (0.60 log units), on the low side; the whole stated range lies below it.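

In this assay, putting 3-chlorophenyl in place of 4-methoxyphenyl gave a 1.0-fold lower number from compound 3 to compound 4 (0.01 log units; within the scatter), so on this core the swap produced no difference that can be told apart from the usual scatter of repeated measurements. Set beside the earlier case, the same change did not keep its size from one core to the other: the same change on two cores in this assay, a 4.0-fold lower number (0.61 log units; beyond the scatter) from compound 2 to compound 1 and a 1.0-fold lower number (0.01 log units; within the scatter) from compound 3 to compound 4, 3.9-fold (0.59 log units) apart, beyond the scatter of two such steps. This shows that a step measured on one core cannot simply be applied to a value on another core in this series, but two pairs do not show which feature of the cores sets the size of the step, nor what the change would do on a further core.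

On these data alone, it remains open whether a third core would give a clear step, as the core of compound 1 does, or none, as the core of compound 4 does. Also open, as far as these compounds go, is how either core would respond if this aromatic carbon carried a different group, such as an amine or a carboxylic acid.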